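The source may report more compounds than this note shows. Statements on the series, on what has been measured and on what is new or still open speak of the compounds shown alone.

In a functional assay on HeLa cells (Homo sapiens) for antiproliferative activity, read by CCK-8 assay, with a stated time of 72 h (a higher number here means a weaker inhibitor, a lower number a stronger inhibitor), compound 1 (`COc1ccc(SCc2ccc(C(=O)Nc3ccccc3N)cc2)cc1`) gives 2390 nM and compound 2 (`CCc1ccc(SCc2ccc(C(=O)Nc3ccccc3N)cc2)cc1`) gives 3800 nM while compound 3 (`Nc1ccccc1NC(=O)c1ccc(CSc2cccc(F)c2)cc1`) gives 3240 nM on the same read-out. Compound 3 stands within the scatter of both of the others, so the three cannot be ranked against one another. Compound 4 (`Cc1ccc(SCc2ccc(C(=O)Nc3ccccc3N)cc2)cc1`) has not yet been measured. It differs from compound 3 in a single place (4-methylphenyl in place of 3-fluorophenyl on a sulfur), with 4-methylphenyl in place of 3-fluorophenyl on a sulfur. Two measured steps exchange the group on that sulfur for 3-fluorophenyl (a 1.4-fold higher number from compound 1 to compound 3 (0.13 log units; within the scatter) and a 1.2-fold lower number from compound 2 to compound 3 (0.07 log units; within the scatter)) and a third exchanges methoxy for ethyl on the aromatic ring (a 1.6-fold higher number from compound 1 to compound 2 (0.20 log units; within the scatter)). All three are small and lie within the scatter, so they give no ground for a direction. The group entering in compound 4 also carries a substituent at the same numbered position as the groups of compound 1 and compound 2, whose values show no gap beyond the scatter. The expected change is a 1.1-fold lower number from compound 3 to compound 4 (0.03 log units; within the scatter) and nothing beyond the scatter is anticipated. Compound 4 is estimated at 3000 nM with an expected range from 1700 nM to 5200 nM in this series.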

Compound 4, half-maximal inhibitory concentration: 4250 nM
Compound 4: middle estimate off by 1.4-fold (0.15 log units), on the low side, and the stated range covers the measured number.
By their numbers in this assay, from the lowest: compounds 1, 3, 2 and 4 (each within the scatter of the next).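

In this assay, the exchange of 3-fluorophenyl for 4-methylphenyl on the sulfur gives a 1.3-fold higher number from compound 3 to compound 4 (0.12 log units; within the scatter) and adds a fourth aromatic group at this position without a step beyond the scatter. Shortening the ethyl group of compound 2 to the methyl group of compound 4 gives a 1.1-fold higher number from compound 2 to compound 4 (0.05 log units; within the scatter) and the exchange of methoxy for methyl gives a 1.8-fold higher number from compound 1 to compound 4 (0.25 log units; within the scatter), which is the largest step among the four compounds and still lies within the scatter, so 3-fluorophenyl, 4-methylphenyl, 4-ethylphenyl and 4-methoxyphenyl on this sulfur cannot be told apart in this assay. No measurement bears on the reason for these small steps.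

The compounds shown cover only substituted phenyl groups on the sulfur, so they leave open whether a phenyl ring carrying an amine or a carboxylic acid, or a longer chain such as butyl on the ring, would give a step beyond the scatter. They also leave open whether a saturated chain in place of the phenyl ring, or an oxygen in place of the sulfur, would keep the number in the same range.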